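Working notes: aryl exchange on the ring amine, compound 4

The source may report more compounds than this note shows. Statements on the series, on what has been measured and on what is new or still open speak of the compounds shown alone.

Measured so far:
compound 1, `Nc1scc(CN2CCN(c3cccnc3)CC2)c1C(=O)c1ccc(Cl)cc1`, -23%
compound 2, `Nc1scc(CN2CCC(c3ccc(Cl)cc3)CC2)c1C(=O)c1ccc(Cl)cc1`, -61%
compound 3, `Nc1scc(CN2CCN(c3cccc(F)c3)CC2)c1C(=O)c1cccc(C(F)(F)F)c1`, -62%

In a functional assay on CHO cells with adenosine receptor A1 (Homo sapiens) as the target, read by cAMP accumulation and immunoassay, with a stated time of 6 min, tested at 10 uM (a higher number here means a weaker effect of the compound at the concentration tested, a lower number a stronger effect), compound 1 gives -23%, the highest of the three numbers, and so the weakest effect shown here. Compound 2 gives -61% and compound 3 gives -62%; both lie beyond the scatter below compound 1, while the two of them lie within the scatter of each other, so no order between compound 2 and compound 3 can be read.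

Compound 4, `Nc1scc(CN2CCN(c3c(F)cc(F)cc3F)CC2)c1C(=O)c1ccc(Cl)cc1`, has not yet been measured in this assay. It differs from compound 1 in one place: 2,4,6-trifluorophenyl in place of pyridin-3-yl on an amine nitrogen in a ring. Among the compounds with values here, no measured pair differs in this single place, so the size of the step cannot be taken from the data. Compound 3, which also carries a fluorine-bearing phenyl on an amine nitrogen in a ring, gives -62%, which is the only hint available.

Compound 4 is expected to give -50%, with a range from -75% to -20%. The expected step from compound 1 to compound 4 is a number 27 percentage points lower from compound 1 to compound 4 (beyond the scatter), a move toward a stronger effect, beyond the scatter but uncertain in size.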

Compound 4, a percentage reported as activity, at one concentration (the size of the read-out at that concentration, not a potency): -78%
Estimate against measurement, compound 4: 28 percentage points above; the measured number lies below the stated range.
By their numbers in this assay, from the lowest: compound 4; then compounds 3 and 2 (each within the scatter of the next); then compound 1.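

Within the data shown here, the exchange of pyridin-3-yl for 2,4,6-trifluorophenyl on an amine nitrogen in a ring gives the first single-place step: in this assay, the read-out shows a number 55 percentage points lower from compound 1 to compound 4 (beyond the scatter). This shows that, with the rest of compound 1 unchanged, the aryl group at this position alone can shift the read-out substantially toward a stronger effect. The change replaces a ring with one hetero atom and one hydrogen-bond acceptor with a carbon-only ring bearing three fluorines and no hydrogen-bond acceptor, but no independent measurement is available to explain the shift.

This one pair cannot separate the loss of the ring nitrogen from the gain of the fluorines, since both change together in the step. Plain phenyl or a pyridine ring bearing fluorine at this place would be needed to divide the step into those two parts, and it remains open whether a step of this size would recur with a different aryl group on the carbonyl.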